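A bromo-for-methoxy swap at the limit of growth inhibition

The source may hold more compounds than are shown below. What is called first, only, known or untested is meant among the compounds shown, and "the series" means these compounds.

Measured so far:
compound 1, `COc1ccc(Cn2ncc(NCCOc3ccccc3OC)c(Cl)c2=O)cc1OC`: 33100 nM
compound 2, `COc1ccc(Cn2nc(NCCOc3ccccc3OC)ccc2=O)cc1OC`: > 100000 nM (a limit)
compound 3, `COc1ccccc1OCCNc1cnn(Cc2ccc(OC(F)F)c(OC3CCCC3)c2)c(=O)c1Cl`: > 100000 nM (a limit)

In a functional assay on SH-SY5Y cells (Homo sapiens) for antiproliferative activity, read by MTT assay, with a stated time of 48 h (a lower number here means a stronger inhibitor of growth, a higher number a weaker inhibitor of growth), compound 1 gives 33100 nM. For compound 2 the assay reports only > 100000 nM, which is a limit and not a number. For compound 3 it likewise reports only > 100000 nM, a limit. Compound 2 therefore stands at the weak end of what is shown, since the limit of > 100000 nM in this assay, at which 2 of the 3 values shown sit, marks where two of the three values sit; compound 1 is the one compound with a measured number.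

The step goes from compound 2 to compound 4, `COc1ccc(Cn2nc(NCCOc3ccccc3OC)ccc2=O)cc1Br`. The change is bromo in place of methoxy on an aromatic carbon, ortho to a methoxy group and meta to a large group, so that the 3,4-dimethoxyphenyl becomes a 3-bromo-4-methoxyphenyl. For the measured compounds named here, no measured step of this kind exists here, and the starting point is itself a limit, so the size of the step in this assay cannot be read from the data. He expects no change beyond the scatter, which is an estimated step of a number no higher from compound 2 to compound 4 (the limit leaves the size open). For compound 4 he expects a value of about 100000 nM, within a range from 30000 nM to 300000 nM.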

Compound 4, concentration for 50% growth inhibition: > 100000 nM
Compound 4: only a limit was reported; the forecaster's own chance of this, stated with the estimate: 65%; the middle value sits exactly at the limit.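

In this assay compound 4 gives > 100000 nM, which is a limit and not a number. Compound 2 also carries only a limit, and the step between compound 2 and compound 4 cannot be read. The compounds shown leave open whether bromo in place of methoxy on an aromatic carbon changes growth inhibition at all.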